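From Compound 2 to Compound 4: a Thiazole Swap

The compounds below may be only part of what the source reports. "The series", "measured", "known", "first", "only" and "open" are said of these compounds alone.

Compound 2 `Cc1noc(C)c1-c1ccc2c(c1)C(c1ccccc1)N(Cc1ncc(-c3ccccc3)o1)C(=O)N2C` stands highest of the three numbers in a functional assay on HCT-116 cells (Homo sapiens) for inhibition, read by MTT assay, with a stated time of 48 h, tested at 2 uM (on this read-out lower numbers stand for less inhibition and higher numbers for more inhibition at the one concentration tested (going by the name of the read-out)), giving 30%; its nearest neighbour is compound 3 `Cc1nc(-c2ccccc2)sc1CN1C(=O)N(C)c2ccc(-c3c(C)noc3C)cc2C1c1ccccc1` with 28.3%, and the furthest is compound 1 `Cc1noc(C)c1-c1ccc2c(c1)C(c1ccccc1)NC(=O)N2C` with 27.8%, both within the scatter. Compound 4 `Cc1noc(C)c1-c1ccc2c(c1)C(c1ccccc1)N(Cc1nc(-c3ccc(F)cc3)cs1)C(=O)N2C` differs from compound 2 by a single change: 4-(4-fluorophenyl)-1,3-thiazol-2-yl in place of 5-phenyl-1,3-oxazol-2-yl on a saturated chain carbon bound to an amide-type nitrogen in a ring. Within the data shown here, two measured steps bear on it: a number 2.2 percentage points higher from compound 1 to compound 2 (within the scatter) and a number 1.7 percentage points lower from compound 2 to compound 3 (within the scatter), neither of them beyond the scatter. Because a number 1.7 percentage points lower from compound 2 to compound 3 (within the scatter) showed that exchanging one arylazole arm for another left the read-out within the scatter, the step of no change at the digits printed from compound 2 to compound 4 (within the scatter) is expected to lie within the scatter as well. Compound 4 is therefore estimated at 30%, with a range from 20% to 40%.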

Compound 4, a percentage reported as inhibition, at one concentration (the size of the read-out at that concentration, not a potency): 33.3%
Beside the measured number, compound 4's estimate is 3.3 percentage points below it, within the range that was stated.
By their numbers in this assay, from the lowest: compounds 1, 3, 2 and 4 (each within the scatter of the next).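

In this assay, the change to 4-(4-fluorophenyl)-1,3-thiazol-2-yl gives a number 3.3 percentage points higher from compound 2 to compound 4 (within the scatter) and a number 5 percentage points higher from compound 3 to compound 4 (within the scatter). A fluorine-bearing arm on the saturated chain carbon, with its azole joined at a different point from that of compound 3, therefore still leaves this position within the scatter. Nothing available explains this result.

The compounds shown leave open what the fluorine contributes, which 4-phenyl-1,3-thiazol-2-yl would isolate. They also leave open whether an arm of another kind, such as a carboxylic acid or an amine on a longer chain, would move the read-out beyond the scatter.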